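Replacing the acetylpiperidine with a hydroxymethylpyridine

A few compounds are considered here, and "the series" means these few. Any claim that something is new, unique, unknown or untested is made for them only; others in the source may bear on it.

Measured compounds:
compound 1, `Cc1cc(-c2cnc(NCc3c(F)ccc4c3CCO4)c3cn[nH]c(=O)c23)n(C)n1`, 24 mL.min-1.g-1
compound 2, `CNC(=O)c1ccc(-c2cnc(NCc3c(F)ccc4c3CCO4)c3cn[nH]c(=O)c23)c(C)n1`, 23 mL.min-1.g-1
compound 3, `CC(=O)N1CCC(c2cnc(NCc3c(F)ccc4c3CCO4)c3cn[nH]c(=O)c23)CC1`, 207 mL.min-1.g-1

In an ADME assay on microsomes from liver (Homo sapiens) for metabolic stability, read by LC-MS, using NADPH, with stated times of 5 min and 30 min, tested at 1 uM (on this read-out higher numbers stand for fast clearance and lower numbers for slow clearance), compound 3 gives 207 mL.min-1.g-1, the highest number of the three. Its nearest neighbour on this read-out is compound 1 with 24 mL.min-1.g-1, and the step of an 8.6-fold higher number from compound 1 to compound 3 (0.94 log units; beyond the scatter) is beyond the scatter. Compound 2, with 23 mL.min-1.g-1, lies furthest away; the step of a 9.0-fold higher number from compound 2 to compound 3 (0.95 log units; beyond the scatter) is likewise beyond the scatter. Between compound 1 and compound 2 the step of a 1.0-fold lower number from compound 1 to compound 2 (0.02 log units; within the scatter) is within the scatter, so both aromatic groups sit at the same level, while the 1-acetylpiperidin-4-yl stands clearly apart.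

Compound 4, `Cc1nc(CO)ccc1-c1cnc(NCc2c(F)ccc3c2CCO3)c2cn[nH]c(=O)c12`, has not yet been measured in this assay. It differs from compound 3 in one place: 6-(hydroxymethyl)-2-methylpyridin-3-yl in place of 1-acetylpiperidin-4-yl on an aromatic carbon. The relevant comparisons are the steps from compound 1 and from compound 2 to compound 3, where an aromatic group was exchanged for the 1-acetylpiperidin-4-yl and the number rose well beyond the scatter. Compound 4 reverses that exchange, bringing in a pyridine that resembles the 2-methyl-6-(methylcarbamoyl)pyridin-3-yl of compound 2 except for the 6-hydroxymethyl group. A drop of about the same size as those steps is therefore expected, that is a 5.9-fold lower number from compound 3 to compound 4 (0.77 log units; beyond the scatter).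

Compound 4 is accordingly estimated at 35 mL.min-1.g-1 in this assay, within a range from 14 mL.min-1.g-1 to 90 mL.min-1.g-1.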

Compound 4, intrinsic clearance in microsomes: 11 mL.min-1.g-1
Compound 4: middle estimate off by 3.2-fold (0.50 log units), on the high side; measured number below the stated range.
By their numbers in this assay, from the lowest: compound 4; then compounds 2 and 1 (each within the scatter of the next); then compound 3.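

In this assay, going by these compounds alone, the 6-(hydroxymethyl)-2-methylpyridin-3-yl and the 1-acetylpiperidin-4-yl match in their counts of heavy atoms, yet exchanging the non-aromatic ring for the aromatic one gives a 19-fold lower number from compound 3 to compound 4 (1.27 log units; beyond the scatter), the only step printed as large. Within the data shown here, the earlier compounds showed only that two aromatic groups could not be told apart on this read-out, whereas the new group separates from both, with a 2.1-fold lower number from compound 2 to compound 4 (0.32 log units; beyond the scatter) and a 2.2-fold lower number from compound 1 to compound 4 (0.34 log units; beyond the scatter), each modest but beyond the scatter. This position therefore responds not only to the choice between a non-aromatic and an aromatic ring but also to the group carried on the aromatic ring, since hydroxymethyl in place of methylcarbamoyl on the same pyridine is enough to change the number.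

Nothing shown here accounts for these differences in clearance. Also open, from the compounds shown here alone, is how the same pyridine would behave with a carboxylic acid, an aminomethyl group or a longer hydroxyalkyl chain in place of the hydroxymethyl, and whether a hydroxymethyl on the 1,3-dimethyl-1H-pyrazol-5-yl would give a similar step.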